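Two Measured Side Chains and a Fluorinated Third

The compounds below may be only part of what the source reports. "The series", "measured", "known", "first", "only" and "open" are said of these compounds alone.

Measured in a functional assay on HeLa cells (Homo sapiens) for cytotoxicity, read by WST assay, with a stated time of 48 h; on this read-out lower numbers stand for stronger inhibition and higher numbers for weaker inhibition:
Compound 1 `COC[C@H](C(C)C)C(c1ccc(O)c(OC)c1)c1ccc(O)c(OC)c1`: 76000 nM
Compound 2 `CCCCC[C@H](C(C)C)C(c1ccc(O)c(OC)c1)c1ccc(O)c(OC)c1`: 9200 nM

Of these two, compound 2 gives the lower number, 9200 nM. The next compound to be tested is compound 3 `COc1cc(C(c2ccc(O)c(OC)c2)[C@H](C)[C@H](C)CF)ccc1O`. It carries 2-(fluoromethyl)-1-methylpropyl in place of 1-isopropylhexyl on a saturated chain carbon bound to two aromatic carbons.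

Among the compounds with values here, only one measured step bears on this change: an 8.3-fold lower number from compound 1 to compound 2 (0.92 log units; beyond the scatter). There, butyl took the place of methoxy, and the step is modest but beyond the scatter. That butyl lies within the 1-isopropylhexyl group that leaves, so compound 3 no longer has it. Within the data shown here, no measured compound carries fluorine, so the data say nothing directly about the fluoromethyl part.

In this assay a higher number is therefore expected, in a step somewhat smaller than the measured one, since compound 1 without the butyl gives 76000 nM. The expected step is a 5.4-fold higher number from compound 2 to compound 3 (0.74 log units; beyond the scatter). For compound 3 the estimate is 50000 nM, with an expected range from 18000 nM to 130000 nM.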

Compound 3, half-maximal inhibitory concentration: 75000 nM
Compound 3: the middle estimate sits 1.5-fold (0.18 log units) below what was measured, and the stated range covers the measured number.
By their numbers in this assay, from the lowest: compound 2; then compounds 3 and 1 (each within the scatter of the next).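

In this assay, the replacement of 1-isopropylhexyl by 2-(fluoromethyl)-1-methylpropyl on the saturated chain carbon bound to two aromatic carbons gives an 8.2-fold higher number from compound 2 to compound 3 (0.91 log units; beyond the scatter), so a substantially different side chain also loses the lower number seen with compound 2. The comparison with the methoxy-bearing side chain gives a 1.0-fold lower number from compound 1 to compound 3 (0.01 log units; within the scatter), which places the fluorinated and methoxy-bearing side chains level at this position and leaves 1-isopropylhexyl as the only one of the three side chains that stands apart from the others. No available evidence gives a reason for these differences in the cytotoxicity numbers.

Compound 3 differs from compound 2 in the whole side chain, so the shown data cannot separate any contribution of the fluoromethyl part from the loss of the 1-isopropylhexyl group, a question that a hydroxymethyl or a plain ethyl in place of fluoromethyl could address. As far as these compounds go, it also remains open whether a chain longer than the one in 1-isopropylhexyl, or an amine at the end of that chain, would lower the number further or raise it.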